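From Sulfonyl to Aminoacetyl on the Ring Nitrogen

The source may report more compounds than this note shows. Statements on the series, on what has been measured and on what is new or still open speak of the compounds shown alone.

Three compounds with a shared core have been measured in a functional assay on PC-3 cells (Homo sapiens) for cytotoxicity, read by MTT assay, with a stated time of 48 h; a higher number here means a weaker inhibitor, a lower number a stronger inhibitor:

compound 1, `O=C(c1ccccc1)N1N=C(c2cc3ccccc3oc2=O)CC1c1ccccc1`, gives 5870 nM
compound 2, `O=C(CCl)N1N=C(c2cc3ccccc3oc2=O)CC1c1ccccc1`, gives 2980 nM
compound 3, `Cc1ccc(S(=O)(=O)N2N=C(c3cc4ccccc4oc3=O)CC2c2ccccc2)cc1`, gives 48600 nM

Compound 3 stands at the highest number of the three. Its nearest neighbour is compound 1, with an 8.3-fold higher number from compound 1 to compound 3 (0.92 log units; beyond the scatter); furthest is compound 2, with a 16-fold higher number from compound 2 to compound 3 (1.21 log units; beyond the scatter). The step from compound 1 to compound 2, a 2.0-fold lower number from compound 1 to compound 2 (0.29 log units; within the scatter), shows that swapping one acyl group for another on the ring nitrogen changed little, while the exchange of an acyl for the sulfonyl group made the number climb.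

Compound 4, `CCNCC(=O)N1N=C(c2cc3ccccc3oc2=O)CC1c1ccccc1`, has not yet been measured. It differs from compound 3 in one place: ((ethylamino)methyl)carbonyl in place of (4-methylphenyl)sulfonyl on an amine nitrogen in a ring. The change runs in the opposite direction from the two steps that raised the number, since it returns an acyl group to the ring nitrogen. The step from compound 2 to compound 3 bears most directly, being the swap of an acyl group for the sulfonyl, and it was large. The step from compound 1 to compound 3 was modest in the same direction.

Compound 4 is therefore expected to show a substantially lower number in this assay, a step of about a 12-fold lower number from compound 3 to compound 4 (1.08 log units; beyond the scatter). The estimate for compound 4 is 4000 nM, with a range from 1500 nM to 12000 nM.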

Compound 4, half-maximal inhibitory concentration: 5580 nM
Estimate against measurement, compound 4: 1.4-fold (0.14 log units) below; the range from low to high includes it.
By their numbers in this assay, from the lowest: compounds 2, 4 and 1 (each within the scatter of the next); then compound 3.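

With the ((ethylamino)methyl)carbonyl group on the amine nitrogen in the ring, this assay gives an 8.7-fold lower number from compound 3 to compound 4 (0.94 log units; beyond the scatter) and so shows that the number can also come down from that of compound 3 with a carbonyl-linked group that has no ring and carries a hydrogen-bond donor. Neither the change at the saturated chain carbon, with a 1.9-fold higher number from compound 2 to compound 4 (0.27 log units; within the scatter) for ethylamino in place of chloro, nor the change on the carbonyl carbon, with a 1.1-fold lower number from compound 1 to compound 4 (0.02 log units; within the scatter) for (ethylamino)methyl in place of phenyl, moves the number beyond the scatter. Among the four compounds, the three carbonyl-linked groups therefore stay together despite their different ends, while the (4-methylphenyl)sulfonyl group of compound 3 stands apart, and no listed compound goes against this.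

With only one sulfonyl compound shown, it remains open whether the high number follows the sulfonyl link or its 4-methylphenyl part, a question that a methylsulfonyl group on the same nitrogen would address, as a longer chain or a carboxylic acid on the acetyl carbon would test how far the carbonyl-linked series holds. No supporting measurement is available to explain why the sulfonyl compound differs from the other three.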